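The compounds below may be only part of what the source reports. "The series", "measured", "known", "first", "only" and "open" are said of these compounds alone.

The measured compounds are:
compound 1, `Cn1cccc(NCc2cc3cc(Cl)ccc3[nH]c2=O)c1=O`, which in a physicochemical assay for solubility (on this read-out lower numbers stand for lower solubility and higher numbers for higher solubility), gives 54000 nM;
compound 2, `C[C@H](Nc1ccc(C#N)n(C)c1=O)c1cc2cc(Cl)c(OCc3ccccn3)cc2[nH]c1=O`, which in this assay gives 2500 nM;
compound 3, `CCn1cccc(NCc2cc3cc(Cl)ccc3[nH]c2=O)c1=O`, which in this assay gives 10000 nM.

Compound 3 differs from compound 1 by methyl in place of hydrogen on a saturated chain carbon bound to an aromatic nitrogen, and this change gave a 5.4-fold lower number from compound 1 to compound 3 (0.73 log units; beyond the scatter). Compound 2 stands lowest of the three in this assay; its nearest neighbour is compound 3 and its furthest is compound 1. The difference between the core of compound 2 and the core of compound 1 is not broken down here.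

The unmeasured compound 4, `C[C@H](Nc1ccc(C#N)n(C)c1=O)c1cc2cc(Cl)c(O[C@H](C)c3ccccn3)cc2[nH]c1=O`, differs from compound 2 by methyl in place of hydrogen on a saturated chain carbon bound to an aromatic carbon and an oxygen on an aromatic ring. Going by the values given here, this is the same kind of change as the one from compound 1 to compound 3, but the place is not the same: there the saturated chain carbon is bound to an aromatic nitrogen, here it is bound to an aromatic carbon and an oxygen on an aromatic ring. Because the earlier change gave a 5.4-fold lower number from compound 1 to compound 3 (0.73 log units; beyond the scatter), the expected step in the same direction, carrying more uncertainty, is estimated as a 3.1-fold lower number from compound 2 to compound 4 (0.49 log units; beyond the scatter). Compound 4 is therefore estimated at 800 nM, between 300 nM and 2500 nM.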

Compound 4, solubility: 1600 nM
The estimate for compound 4 lay 2.0-fold (0.30 log units) below the measured number; measured number inside the range.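

Placed on the saturated chain carbon bound to an aromatic carbon and an oxygen on an aromatic ring, the methyl gave in this assay a 1.6-fold lower number from compound 2 to compound 4 (0.19 log units; within the scatter), so compound 2 and compound 4 cannot be told apart on this read-out. The same kind of change on the saturated chain carbon bound to an aromatic nitrogen gave a 5.4-fold lower number from compound 1 to compound 3 (0.73 log units; beyond the scatter), so the size of that step did not carry over to the core of compound 2, but with a single pair for each core and a different place in each, this shows no rule for the series. Nothing available accounts for the difference between the two results.

The compounds shown leave open how a longer chain, such as ethyl, or an amine or a carboxylic acid would read in place of the methyl on this saturated chain carbon. They also leave open how the 1-(pyridin-2-yl)ethoxy group would read with the opposite configuration at that carbon.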